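Phenolic diol series: the configuration change from compound 3 to compound 4

The source may hold more compounds than are shown below. What is called first, only, known or untested is meant among the compounds shown, and "the series" means these compounds.

Measured compounds in a functional assay on U-937 cells (Homo sapiens) for antiproliferative activity, read by MTT assay, with a stated time of 48 h; a lower number here means a stronger inhibitor, a higher number a weaker inhibitor:
compound 1, `Oc1ccc(CC[C@H](O)C[C@@H](O)CCc2ccccc2)cc1`, gives 31.1 ug/mL
compound 2, `Oc1ccc(CC[C@@H](O)C[C@@H](O)CCc2ccccc2)cc1`, gives 33 ug/mL
compound 3, `COc1cc(CC[C@H](O)C[C@@H](O)CCc2ccccc2)ccc1O`, gives 27.7 ug/mL

Compound 3 has the lowest number of the three shown, but its gaps to compound 1 and compound 2 are both within the scatter, so the three sit together. The step to the methoxy analogue, a 1.1-fold lower number from compound 1 to compound 3 (0.05 log units; within the scatter), likewise stays within the scatter.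

Compound 4, `COc1cc(CC[C@@H](O)C[C@@H](O)CCc2ccccc2)ccc1O`, differs from compound 3 as follows: the two compounds have the same atoms and bonds and differ only in configuration as drawn: 1 of 2 stereo elements differ; a stereocentre at a saturated chain carbon is drawn S in compound 3 and R in compound 4. The same change has already been measured once in this series, on the pair without the methoxy group, where a 1.1-fold higher number from compound 1 to compound 2 (0.03 log units; within the scatter) was observed. That pair is informative because of the fact that compounds 1 and 2 differ only in the configuration as drawn, so the configuration is the only thing that separates the two values. Nothing in the measured steps indicates that the methoxy group alters this picture: the two changes, configuration and methoxy, each gave no movement beyond the scatter.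

For compound 4 in this assay no step beyond the scatter is therefore expected; the estimated step is a 1.1-fold higher number from compound 3 to compound 4 (0.03 log units; within the scatter). Compound 4 is estimated at 30 ug/mL, with a range from 18 ug/mL to 48 ug/mL.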

Compound 4, half-maximal inhibitory concentration: 32.7 ug/mL
Estimate against measurement, compound 4: 1.1-fold (0.04 log units) below; the measured number falls inside the stated range.
By their numbers in this assay, from the lowest: compounds 3, 1, 4 and 2 (each within the scatter of the next).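

In this assay, the configuration change at the saturated chain carbon can now be read with and without the methoxy group, and a 1.2-fold higher number from compound 3 to compound 4 (0.07 log units; within the scatter) stays within the scatter, as a 1.1-fold higher number from compound 1 to compound 2 (0.03 log units; within the scatter) does. The step on the methoxy pair can be assigned to the stereocentre alone: the fact that compounds 3 and 4 differ only in the configuration as drawn. The methoxy replacement can also now be read in both drawn configurations, with a 1.0-fold lower number from compound 2 to compound 4 (0.00 log units; within the scatter) alongside a 1.1-fold lower number from compound 1 to compound 3 (0.05 log units; within the scatter), and the two readings agree: the same change on two cores in this assay, a 1.1-fold lower number (0.05 log units; within the scatter) from compound 1 to compound 3 and a 1.0-fold lower number (0.00 log units; within the scatter) from compound 2 to compound 4, 1.1-fold (0.05 log units) apart, within the scatter of two such steps.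

Across these four compounds, neither the configuration at this carbon nor methoxy in place of hydrogen on an aromatic carbon gives a step beyond the scatter in this assay, but the drawn configuration at the other stereocentre is the same in all four, so its contribution remains open. Also open, going by these compounds, is whether a carbonyl in place of a chain hydroxyl, an amine or carboxylic acid on the aromatic ring, or a longer chain would give a step beyond the scatter.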